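Working notes: nitro in place of methoxycarbonyl

The compounds below may be only part of what the source reports. "The series", "measured", "known", "first", "only" and "open" are said of these compounds alone.

Measured in a functional assay on a cell-free system (plasma, Oryctolagus cuniculus) for inhibition, with stated times of 5 min, 1 min and 6 min; on this read-out higher numbers stand for weaker inhibition and lower numbers for stronger inhibition:
- compound 1 `CCOC(=O)c1c(C)nc(-c2cccc(C#N)c2)n1OCCCO`: 11400 nM
- compound 2 `CCOC(=O)c1c(C)nc(-c2cccc(C#N)c2)n1OCc1ccccc1`: 5930 nM
- compound 3 `CCOC(=O)c1c(C)nc(-c2cccc(C#N)c2)n1OCc1ccc(C(=O)OC)cc1`: 9470 nM

Compound 3 cannot be separated from the other two compounds: the data show a 1.2-fold lower number from compound 1 to compound 3 (0.08 log units; within the scatter) and a 1.6-fold higher number from compound 2 to compound 3 (0.20 log units; within the scatter). Compound 4 `CCOC(=O)c1c(C)nc(-c2cccc(C#N)c2)n1OCc1ccc([N+](=O)[O-])cc1` has nitro in place of methoxycarbonyl on an aromatic carbon, para to a large group: nitro in place of methoxycarbonyl on an aromatic carbon. The nearest evidence is the exchange of hydrogen for methoxycarbonyl on that aromatic carbon, which gave a 1.6-fold higher number from compound 2 to compound 3 (0.20 log units; within the scatter). The exchange on the chain carbon gave a 1.9-fold lower number from compound 1 to compound 2 (0.28 log units; within the scatter) and a 1.2-fold lower number from compound 1 to compound 3 (0.08 log units; within the scatter). None of these steps leaves the scatter, so no step beyond the scatter is expected in this assay. The expected change is a 1.2-fold lower number from compound 3 to compound 4 (0.07 log units; within the scatter). For compound 4 the estimated value is 8000 nM, expected to fall between 3800 nM and 16000 nM.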

Compound 4, half-maximal inhibitory concentration: 8750 nM
Compound 4: the middle estimate sits 1.1-fold (0.04 log units) below what was measured, and the stated range covers the measured number.
By their numbers in this assay, from the lowest: compounds 2, 4, 3 and 1 (each within the scatter of the next).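

In this assay, nitro in place of methoxycarbonyl on the aromatic carbon para to a large group stays within the scatter (a 1.1-fold lower number from compound 3 to compound 4 (0.03 log units; within the scatter)). Nitro in place of hydrogen on that carbon also stays within it (a 1.5-fold higher number from compound 2 to compound 4 (0.17 log units; within the scatter)), as does 4-nitrophenyl in place of 2-hydroxyethyl (a 1.3-fold lower number from compound 1 to compound 4 (0.11 log units; within the scatter)), so neither nitro nor methoxycarbonyl at this position separates from hydrogen. No measured property bears on these results.

From the compounds shown here alone, whether an amine or a carboxylic acid on that aromatic carbon would give a step beyond the scatter remains open.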